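The source may report more compounds than this note shows. Statements on the series, on what has been measured and on what is new or still open speak of the compounds shown alone.

Measured so far:
compound 1 `CCNC(=O)CCc1cccc2c1B(O)OC2`: > 100000 nM
compound 2 `O=C(CCc1cccc2c1B(O)OC2)Nc1cccc(Br)c1`: 540 nM

Both readings come from a functional assay on SK-OV-3 cells (Homo sapiens) for antiproliferative activity, read by MTT assay, with a stated time of 72 h; a lower number here means a stronger inhibitor, a higher number a weaker inhibitor. For compound 1 the reading is a limit of the assay, not a number. Among the measured compounds shown here, compound 2, at 540 nM, holds the only actual number.

Next is compound 3 `O=C(CCc1cccc2c1B(O)OC2)Nc1cccc(-c2ccccc2)c1`, with phenyl in place of bromo on an aromatic carbon, meta to a large group: phenyl in place of bromo on an aromatic carbon. For the measured compounds named here, one measured step bears on this change: an at least 180-fold lower number from compound 1 to compound 2 (2.26 log units; beyond the scatter). That large step replaced ethyl with 3-bromophenyl on an amide-type nitrogen, so it does not directly size a swap that keeps this ring in place. A modest step in this assay is expected, leaning slightly towards a higher number, and it may stay within the scatter. For compound 3 the estimated value is 700 nM, with an expected range of 170 nM to 3000 nM. The expected change is a 1.3-fold higher number from compound 2 to compound 3 (0.11 log units; within the scatter).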

Compound 3, half-maximal inhibitory concentration: 250 nM
For compound 3 the middle estimate is 2.8-fold (0.45 log units) above the measured one; the range from low to high includes it.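

In this assay, phenyl in place of bromo on this aromatic carbon gives a 2.2-fold lower number from compound 2 to compound 3 (0.33 log units; beyond the scatter), a modest step beyond the scatter. The earlier step concerned only the group on the amide-type nitrogen, whereas this one shows that the substituent on that aromatic ring can itself be changed: six carbon atoms and a second aromatic ring enter for a single bromine, and the number still falls. Nothing in the data given accounts for this step.

The compounds shown compare only bromo and phenyl at this place, so the response to a methoxy group, or to a phenyl carrying an amine or a carboxylic acid, remains open. Also open, going by these compounds, is how the ring without any substituent at this place would read.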